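From chloro to methoxy on the shared core

The source may report more compounds than this note shows. Statements on the series, on what has been measured and on what is new or still open speak of the compounds shown alone.

In a functional assay on HCT-116 cells (Homo sapiens) for antiproliferative activity, read by MTT assay, with a stated time of 72 h (on this read-out lower numbers stand for stronger inhibition and higher numbers for weaker inhibition), compound 1 `COc1ccc(N2C(=O)COc3ccc(-c4cnc(Cl)c(NS(=O)(=O)c5ccc(F)cc5)c4)cc32)cc1` gives 30100 nM and compound 3 `Cc1ccc(N2C(=O)COc3ccc(-c4cnc(Cl)c(NS(=O)(=O)c5ccc(F)cc5)c4)cc32)cc1` gives 34300 nM, two values within the scatter of each other. Compound 2 `O=C1COc2ccc(-c3cnc(Cl)c(NS(=O)(=O)c4ccc(F)cc4)c3)cc2N1` reads > 40000 nM, which is a limit and not a number. For the measured compounds named here, compound 1 therefore holds a high number on this read-out, with no measured compound clearly separated from it.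

The next compound, compound 4 `COc1ccc(N2C(=O)COc3ccc(-c4cnc(OC)c(NS(=O)(=O)c5ccc(F)cc5)c4)cc32)cc1`, carries methoxy in place of chloro on an aromatic carbon, next to the ring nitrogen and ortho to a ((4-fluorophenyl)sulfonyl)amino group: methoxy in place of chloro on an aromatic carbon.

The measured steps bear on it only indirectly, as all of them change other places. Hydrogen in place of 4-methoxyphenyl gives an at least 1.3-fold higher number from compound 1 to compound 2 (0.12 log units; that floor lies within the scatter), methyl in place of methoxy gives a 1.1-fold higher number from compound 1 to compound 3 (0.06 log units; within the scatter), and 4-methylphenyl in place of hydrogen gives an at least 1.1-fold lower number from compound 2 to compound 3 (0.06 log units; that floor lies within the scatter). They show that this assay barely separates these compounds, but they say nothing about the chloro position itself.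

Going by the values given here, with compound 1 at 30100 nM, a shift towards a lower number is thought more likely than a rise, though no measurement yet supports this. The expected change is a 5.0-fold lower number from compound 1 to compound 4 (0.70 log units; beyond the scatter), and its size is very uncertain. Compound 4 is estimated at 6000 nM, with an expected range of 400 nM to 35000 nM.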

Compound 4, half-maximal inhibitory concentration: 13400 nM
Compound 4: middle estimate off by 2.2-fold (0.35 log units), on the low side, within the range that was stated.
By their numbers in this assay, from the lowest: compound 4; then compounds 1 and 3 (each within the scatter of the next). At a limit, above all of these: compound 2.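

Methoxy in place of chloro on the aromatic carbon next to the ring nitrogen gives a 2.2-fold lower number from compound 1 to compound 4 (0.35 log units; beyond the scatter) in this assay. This is the only step among these compounds printed as beyond the scatter, so this position moves the read-out in a way that the changes on the amide-type nitrogen and on its aromatic substituent have not shown. The gain is modest, however, and compound 4 still reads 13400 nM; the data also offer no reason for the step, as nothing measured here explains it.

One change at one position cannot show whether the lower number belongs to methoxy in particular or whether other replacements for chloro would do the same, such as an amine, a nitrile or a longer chain like ethoxy. On these data alone, it also remains open whether the same swap would give a comparable step with 4-methylphenyl or hydrogen in place of 4-methoxyphenyl on the amide-type nitrogen, and whether any such step would hold beyond this assay.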